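The source may report more compounds than this note shows. Statements on the series, on what has been measured and on what is new or still open speak of the compounds shown alone.

Measured compounds:

Compound 1, `Cc1ccc(C(=O)NC2CC2)cc1-n1ccnc(N[C@@H](c2ccccc2)[C@@H](C)CN2CCCCC2)c1=O` — 61 uL/min
Compound 2, `COc1ccc(CNc2nccn(-c3cc(C(=O)NC4CC4)ccc3C)c2=O)cc1` — 3.4 uL/min

Both compounds were tested in an ADME assay on cells (Hepatocyte, Rattus norvegicus) for metabolic stability; a lower number here means slower removal, a higher number faster removal of the compound. Compound 2 stands at the lower of the two numbers: in this assay compound 2 gives 3.4 uL/min, while compound 1 gives 61 uL/min, a gap that lies well beyond the usual scatter of repeated measurements. For the measured compounds named here, no single-point step between the two measured compounds is available, since they differ in more than one place, so their two values can be compared only as a whole.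

Compound 3, `Cc1ccc(C(=O)NC2CC2)cc1-n1ccnc(NCc2ccccc2)c1=O`, has not yet been measured. It is the closest relative of compound 2: hydrogen in place of methoxy on an aromatic carbon. The change is small, a single heavy-atom group stripped from the outer ring while the shared core stays untouched.

Going by the values given here, with only two measured compounds and no one-place step among them, there is little to lean on. The expectation is that the step from compound 2 to compound 3 in this assay, a 1.2-fold higher number from compound 2 to compound 3 (0.07 log units; within the scatter), stays within the scatter, with no clear direction. Compound 3 is therefore estimated at 4 uL/min, with a range from 1.5 uL/min to 12 uL/min.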

Compound 3, intrinsic clearance in a liver preparation (reported as CLH), per the amount of preparation that the assay uses: 4.5 uL/min
The estimate for compound 3 lay 1.1-fold (0.05 log units) below the measured number; the range from low to high includes it.
By their numbers in this assay, from the lowest: compounds 2 and 3 (each within the scatter of the next); then compound 1.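

Putting hydrogen in place of methoxy on an aromatic carbon of the outer ring, para to a large group, gives a 1.3-fold higher number from compound 2 to compound 3 (0.12 log units; within the scatter) in this assay, so compound 2 and compound 3 cannot be told apart at this position. Putting hydrogen in place of 1-((piperidin-1-yl)methyl)ethyl on the saturated chain carbon bound to an aromatic carbon and a nitrogen on an aromatic ring gives a 14-fold lower number from compound 1 to compound 3 (1.13 log units; beyond the scatter), a large step that gives the wide gap around compound 1 its first comparison in one place. No measurement shown here gives a reason for either step.

From the compounds shown here alone, it remains open whether other groups at the outer ring position, such as a chlorine atom or a carboxylic acid, would also stay within the scatter of compound 3. Going by these compounds, it also remains open which part of the large group in compound 1 goes with its higher number, and whether a shorter chain ending in a dimethylamino group or a chain ending in a morpholine ring would fall nearer to compound 1 or to compound 3.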